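Cytotoxicity notes on the bicyclic acid series

The source may report more compounds than this note shows. Statements on the series, on what has been measured and on what is new or still open speak of the compounds shown alone.

Both measured members of the set sit at the ceiling of an ADME assay on MT2 cells (Homo sapiens) for cytotoxicity, read by XTT assay, with a stated time of 4 days; on this read-out lower numbers stand for higher toxicity in this test and higher numbers for lower toxicity in this test. Compound 1 `Cc1ccc(-c2c(C(OC(C)(C)C)C(=O)O)c(C)nc3ccccc23)cc1` gives only a limit, > 40000 nM, in this assay. Compound 2 `Cc1ccc(CCCN2CCc3nc(C)c([C@H](OC(C)(C)C)C(=O)O)c(-c4cc(F)c5c(c4C)CCCO5)c3C2)cc1F` likewise gives only a limit, > 40000 nM, in this assay. Within the data shown here, this is the limit of > 40000 nM in this assay, at which 2 of the 2 values shown sit, so neither compound has a numbered value, and no step between measured compounds can be drawn from these two results. Where compound 2 stands is therefore known only as a limit, not as a point.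

Compound 3 `Cc1nc2c(c(-c3cc(F)c4c(c3C)CCCO4)c1[C@H](OC(C)(C)C)C(=O)O)CN(CCCc1ccncc1)CC2` has not yet been run. It differs from compound 2 by pyridin-4-yl in place of 3-fluoro-4-methylphenyl on a saturated chain carbon, three bonds along the chain from an amine nitrogen in a ring. Among the measured compounds shown here, the measured compounds offer no step on which to weigh this change, and no property of the entering pyridin-4-yl or of the leaving 3-fluoro-4-methylphenyl is known from this assay. The expectation is that the step from compound 2 to compound 3 in this assay is none beyond the scatter, a number no higher from compound 2 to compound 3 (the limit leaves the size open). Compound 3 is thus estimated at 40000 nM in this assay, with a range from 15000 nM to 100000 nM, most likely reported as a limit again.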

Compound 3, half-maximal cytotoxic concentration: > 40000 nM
Compound 3 ended at the assay's limit (the forecaster's own chance of this, stated with the estimate: 70%); the middle value sits exactly at the limit.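

No step can be read from compound 2 to compound 3, as neither gives a number in this assay: the limit of > 40000 nM in this assay, at which 3 of the 3 values shown sit.

The compounds shown leave open whether 3-(pyridin-4-yl)propyl in place of 3-(3-fluoro-4-methylphenyl)propyl shifts the half-maximal cytotoxic concentration at all, and where that concentration lies for any of the three compounds.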